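The compounds below may be only part of what the source reports. "The series", "measured", "known", "first", "only" and "open" are said of these compounds alone.

Compound 1 `COc1cc(/C=N/NC(=O)Nc2cc3c(Nc4ccc(F)c(Cl)c4)ncnc3cc2O[C@H]2CCOC2)cc(OC)c1OC`: 26400 nM
Compound 2 `CCN(CC)c1ccc(/C=N/NC(=O)Nc2cc3c(Nc4ccc(F)c(Cl)c4)ncnc3cc2O[C@H]2CCOC2)c(O)c1`: 15700 nM
Compound 3 `O=C(N/N=C/c1ccc(O)cc1)Nc1cc2c(Nc3ccc(F)c(Cl)c3)ncnc2cc1O[C@H]1CCOC1`: 1320 nM

In a functional assay on A549 cells (Homo sapiens) for cytotoxicity, read by MTT assay, with a stated time of 72 h (on this read-out lower numbers stand for stronger inhibition and higher numbers for weaker inhibition), compound 1 stands at the highest of the three numbers. Compound 2 lies within the scatter of it (a 1.7-fold lower number from compound 1 to compound 2 (0.23 log units; within the scatter)), whereas compound 3 is clearly apart (a 20-fold lower number from compound 1 to compound 3 (1.30 log units; beyond the scatter)), and the gap between compound 2 and compound 3 is also large (a 12-fold lower number from compound 2 to compound 3 (1.08 log units; beyond the scatter)).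

Compound 4 `COc1cc2ncnc(Nc3ccc(F)c(Cl)c3)c2cc1NC(=O)N/N=C/c1cc(OC)c(OC)c(OC)c1` differs from compound 1 by methyl in place of oxolan-3-yl on an oxygen on an aromatic ring. All three measured steps change the group on the carbon with a double bond to nitrogen, not this oxygen, so none of them bears on the change. Among the compounds with values here, with no relevant precedent, no step beyond the scatter is expected in this assay in either direction. Compound 4 is therefore expected to give about 26400 nM, with a range of 8000 nM to 85000 nM, which means an expected step of no change at the digits printed from compound 1 to compound 4 (within the scatter).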

Compound 4, half-maximal inhibitory concentration: 32100 nM
Compound 4: middle estimate off by 1.2-fold (0.08 log units), on the low side; measured number inside the range.
By their numbers in this assay, from the lowest: compound 3; then compounds 2, 1 and 4 (each within the scatter of the next, the first and the last beyond it).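

Within the data shown here, at the oxygen on an aromatic ring, where the earlier compounds offered no reading, methyl in place of oxolan-3-yl gives a 1.2-fold higher number from compound 1 to compound 4 (0.08 log units; within the scatter) in this assay. With the 3,4,5-trimethoxyphenyl group held constant, the five-membered ring and its defined stereocentre can therefore be exchanged for methyl without a step beyond the scatter. No measured evidence bears on this result.

The compounds shown leave open whether this exchange would read the same with the 4-hydroxyphenyl group of compound 3. From the compounds shown here alone, how a longer alkyl chain or an amine-bearing chain on this oxygen would read also remains open.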